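A dichlorophenyl for a dimethylphenyl on the ring nitrogen

A few compounds are considered here, and "the series" means these few. Any claim that something is new, unique, unknown or untested is made for them only; others in the source may bear on it.

Of the compounds shown here, three sharing one core have been measured in a functional assay on HL-60 cells (Homo sapiens) for inhibition, read by MTT assay, with a stated time of 72 h; a higher number here means a weaker inhibitor, a lower number a stronger inhibitor. Compound 1 `Cc1nc(-c2cccc(F)c2)c(C(=O)N2CCN(c3cccc(Cl)c3)CC2)o1` gives 33.7 nM. Compound 2 `Cc1nc(-c2ccccc2)c(C(=O)N2CCN(c3cccc(C)c3C)CC2)o1` gives 35 nM. Compound 3 `CCc1nc(-c2cccc(F)c2)c(C(=O)N2CCN(c3cccc(Cl)c3)CC2)o1` gives 317 nM. Within the data shown here, the only single-site step among them is a 9.4-fold higher number from compound 1 to compound 3 (0.97 log units; beyond the scatter), a change at a saturated chain carbon bound to an aromatic carbon. Compound 2 holds the second highest of the three numbers: its nearest neighbour is compound 1, within the scatter, and its furthest is compound 3, beyond it. Among the measured compounds shown here, compounds 1 and 2 differ at two places at once, so no step is counted between them; their values simply show that those two changes together left the number where it was.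

Compound 4 `Cc1nc(-c2ccccc2)c(C(=O)N2CCN(c3cc(Cl)cc(Cl)c3)CC2)o1` has not been measured. It differs from compound 2 by 3,5-dichlorophenyl in place of 2,3-dimethylphenyl on an amine nitrogen in a ring. For the measured compounds named here, no measured step touches this position, and the single step known concerns another part of the molecule, so nothing in the data points to a shift in this assay beyond the scatter. The step from compound 2 is therefore expected to be a 1.1-fold higher number from compound 2 to compound 4 (0.06 log units; within the scatter). Compound 4 is expected to give about 40 nM in this assay. The estimate for compound 4 runs from 15 nM to 120 nM.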

Compound 4, half-maximal inhibitory concentration: 41.8 nM
Beside the measured number, compound 4's estimate is 1.0-fold (0.02 log units) below it; measured number inside the range.
By their numbers in this assay, from the lowest: compounds 1, 2 and 4 (each within the scatter of the next); then compound 3.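

Among these compounds, this is the first measured step at the aryl group on the amine nitrogen in the ring: in this assay, 3,5-dichlorophenyl in place of 2,3-dimethylphenyl leaves the two numbers within the scatter of each other (a 1.2-fold higher number from compound 2 to compound 4 (0.08 log units; within the scatter)). The two groups have the same count of heavy atoms and the same single carbon-only aromatic ring, but they differ both in the kind of substituent and in where the substituents sit, so this exchange as a whole is tolerated here, at least with the unsubstituted phenyl of compound 2 and compound 4 on the other side of the core. Nothing measured on these compounds accounts for why the number held.

Among the compounds shown here, the single pair cannot separate the chlorines from their placement, so a 3-chlorophenyl or a 3,5-dimethylphenyl on this compound 2 and compound 4 scaffold would be needed to tell those two apart. As far as these compounds go, it also remains open whether the position accepts something further from these aryl groups, such as a pyridine ring, a carboxylic acid on the phenyl ring or a saturated cyclohexyl ring.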